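A few compounds are considered here, and "the series" means these few. Any claim that something is new, unique, unknown or untested is made for them only; others in the source may bear on it.

Compound 1 `Nc1ccc(S(=O)(=O)c2ccc(-c3ncc(C(O)(C(F)(F)F)C(F)(F)F)cc3Cl)cc2)cn1` gives 18 mL.min-1.g-1 
Compound 2 `C[C@H](O)C#Cc1cc(C(O)(C(F)(F)F)C(F)(F)F)cnc1-c1ccc(S(=O)(=O)c2ccc(N)nc2)cc1` gives 29 mL.min-1.g-1 
Compound 3 `CCNc1nc(S(=O)(=O)c2ccc(N)nc2)ccc1-c1ccc(C(C)(O)C(F)(F)F)cn1` gives 42 mL.min-1.g-1 

These three numbers all come from an ADME assay (liver) for metabolic stability, with Liver microsome (Rattus norvegicus) as the target, using microsomes and NADPH, with a stated time of 30 min, at 37 degrees C, tested at 1 uM (on this read-out lower numbers stand for slow clearance and higher numbers for fast clearance), and form the starting point. Compound 3 has the highest of the three numbers. Its gap to compound 2 stays within the usual scatter of repeated measurements, so those two cannot be told apart, while its gap to compound 1 goes beyond that scatter.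

Compound 4 `CC(O)(c1ccc(-c2ccc(S(=O)(=O)c3ccc(N)nc3)nc2Nc2cccnc2)nc1)C(F)(F)F` differs from compound 3 in one place: pyridin-3-yl in place of ethyl on a nitrogen on an aromatic ring and so pyridin-3-yl stands in place of ethyl on a nitrogen on an aromatic ring. Put another way, ethylamino becomes (pyridin-3-yl)amino.

The measured data offer little guidance here. Within the data shown here, the one measured step is a 1.6-fold higher number from compound 1 to compound 2 (0.21 log units; within the scatter) and it comes from a different change, 3-hydroxybut-1-yn-1-yl in place of chloro on an aromatic carbon. Among the measured compounds shown here, no measured pair shows any change to the group on this nitrogen, so neither the size nor the direction of the new step can be read from the data. No step beyond the scatter is therefore expected, and the estimated step is a 1.2-fold lower number from compound 3 to compound 4 (0.08 log units; within the scatter) in size. For compound 4 the estimated value is 35 mL.min-1.g-1 and the expected range runs from 14 mL.min-1.g-1 up to 80 mL.min-1.g-1.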

Compound 4, intrinsic clearance in microsomes: 142 mL.min-1.g-1
Compound 4: the middle estimate sits 4.1-fold (0.61 log units) below what was measured; the measured number lies above the stated range.
By their numbers in this assay, from the lowest: compounds 1, 2 and 3 (each within the scatter of the next, the first and the last beyond it); then compound 4.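

In this assay, the group on this nitrogen clearly matters: pyridin-3-yl in place of ethyl gives a 3.4-fold higher number from compound 3 to compound 4 (0.53 log units; beyond the scatter). The only earlier single change, a 1.6-fold higher number from compound 1 to compound 2 (0.21 log units; within the scatter), sat at a different place and stayed within the scatter, so this is the first step among these compounds that clearly separates two close relatives, and here the higher number means faster clearance. Nothing measured here accounts for the rise, so the data show only that it happens, and only in this one pair.

A single pair cannot tell whether the rise goes with the aromatic ring as a whole or with the nitrogen atom inside it, and a phenyl group on the same nitrogen would be the direct comparison. As far as these compounds go, it also remains open how the number would respond to a longer chain such as butyl, to a small saturated ring such as cyclopropyl, or to a plain amine with no group on this nitrogen, and whether the same change would give a similar step on the core of compound 1.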